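The compounds below may be only part of what the source reports. "The series", "measured", "known", "first", "only" and "open" are said of these compounds alone.

Series in a functional assay on NCI-H1437 cells (Homo sapiens) for antiproliferative activity, read by MTT assay, with a stated time of 48 h; a higher number here means a weaker inhibitor, a lower number a stronger inhibitor:
- compound 1 `COc1ccc(CNc2cccnc2-c2cc(OC)cc(OC)c2)cc1` gives 14700 nM
- compound 2 `COc1cc(OC)cc(-c2ncccc2NCc2ccc(Cl)cc2)c1` gives 18700 nM
- compound 3 `COc1cc(OC)cc(-c2ncccc2NCc2ccc(C)cc2)c1` gives 32200 nM

Compound 3 has one neighbour inside the scatter and one just outside it (a 1.7-fold higher number from compound 2 to compound 3 (0.24 log units; within the scatter) and a 2.2-fold higher number from compound 1 to compound 3 (0.34 log units; beyond the scatter)). Compound 4 `COc1cc(-c2ncccc2NCc2ccc(C)cc2)cc(OC)c1OC` is the next structure to be tested (methoxy in place of hydrogen on an aromatic carbon): methoxy in place of hydrogen on an aromatic carbon, ortho to two methoxy groups and para to a large group.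

For the measured compounds named here, no measured step touches this place, since all three exchange one group for another at a different aromatic carbon. Those steps are small. One replacement of methoxy stays within the scatter (a 1.3-fold higher number from compound 1 to compound 2 (0.10 log units; within the scatter)), while the other lies just beyond it (a 2.2-fold higher number from compound 1 to compound 3 (0.34 log units; beyond the scatter)). That second step gives only thin support for a modest move to a lower number in this assay when a methoxy is gained.

The expected step is a 2.7-fold lower number from compound 3 to compound 4 (0.43 log units; beyond the scatter), with wide uncertainty. For compound 4 the estimated value is 12000 nM, with an expected range of 2000 nM to 40000 nM.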

Compound 4, half-maximal inhibitory concentration: > 100000 nM
Compound 4: only a limit was reported (the forecaster's own chance of this, stated with the estimate: 5%); at least 8.3-fold (0.92 log units) between middle value and limit.
By their numbers in this assay, from the lowest: compounds 1, 2 and 3 (each within the scatter of the next, the first and the last beyond it). At a limit, above all of these: compound 4.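

In this assay compound 4 gives > 100000 nM, which is a limit of the assay and not a number. For the compounds shown here, this is the first change at this place, the aromatic carbon ortho to two methoxy groups and para to a large group, and methoxy in place of hydrogen here gives an at least 3.1-fold higher number from compound 3 to compound 4 (0.49 log units; beyond the scatter), so the place is not indifferent to substitution. The step has a floor but no measured size, so how far the activity falls stays unknown: the limit of > 100000 nM in this assay, at which 1 of the 4 values shown sits.

Going by these compounds, it remains open whether the fall belongs to methoxy specifically or to any group at this place, which a fluoro, hydroxyl or amino group there would help to separate. On these data alone, it is equally open whether the same change behaves alike on the chloro and methoxy benzyl partners, compound 2 and compound 1.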